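This account rests on a few compounds, and the source may have more. Where it says the series, first, only, none or still open, it means among the compounds named here.

Series notes. Compound 1 `N/C(=N\NC(=S)N1CCOCC1)c1ccccn1`, compound 2 `Cc1ccnc(/C(N)=N/NC(=S)N2CCOCC2)c1` and compound 3 `Cc1cccc(/C(N)=N/NC(=S)N2CCCC2)n1` have been run in a functional assay on A-375 cells (Homo sapiens) for cytotoxicity, read by MTT assay, with a stated time of 72 h, tested at 30 uM; on this read-out lower numbers stand for less inhibition of growth and higher numbers for more inhibition of growth at the one concentration tested. Compound 1 gives 15%, compound 2 gives 87.4%, and compound 3 gives 60.8%. The step of a number 72.4 percentage points lower from compound 2 to compound 1 (beyond the scatter) follows the change (hydrogen in place of methyl on an aromatic carbon). How the cores of compound 2 and compound 3 differ is not broken down here. Compound 4 `N/C(=N\NC(=S)N1CCCC1)c1ccccn1` is still to be measured in this assay; it arises from compound 3 through (hydrogen in place of methyl on an aromatic carbon). The places differ: in compound 2 the methyl sits opposite the ring nitrogen, in compound 3 next to the ring nitrogen, so this is the same kind of change, not the same one. Given the large drop seen in a number 72.4 percentage points lower from compound 2 to compound 1 (beyond the scatter), a step of about a number 40.8 percentage points lower from compound 3 to compound 4 (beyond the scatter) is expected for compound 4. For compound 4 the estimate is 20%, between 5% and 50%.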

Compound 4, percent growth inhibition at one concentration: 86%
Compound 4: middle estimate off by 66 percentage points, on the low side; the measured number lies above the stated range.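

Hydrogen in place of methyl gives a number 25.2 percentage points higher from compound 3 to compound 4 (beyond the scatter) in this assay, while the same kind of change on the other core runs the opposite way: the same change on two cores in this assay, a number 72.4 percentage points lower (beyond the scatter) from compound 2 to compound 1 and a number 25.2 percentage points higher (beyond the scatter) from compound 3 to compound 4, 97.6 percentage points apart, beyond the scatter of two such steps

The effect of this change therefore does not carry from one core to the other in this series, but the two steps differ both in where the methyl leaves and in the group on the thiocarbonyl carbon, and these pairs do not separate the two. Without the methyl, pyrrolidin-1-yl in place of morpholin-4-yl gives a number 71 percentage points higher from compound 1 to compound 4 (beyond the scatter).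

Open, on these data alone, is how an ethyl or methoxy group on the aromatic ring would read on either core. Also open, as far as these compounds go, is how a piperidine ring or a dimethylamino group would read on the thiocarbonyl carbon.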